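The source may report more compounds than this note shows. Statements on the series, on what has been measured and on what is new or still open speak of the compounds shown alone.

Measured so far in an assay on Sf9 cells for inhibition of protein deacetylase HDAC6 (Homo sapiens), read by fluorescence; a lower number here means a stronger inhibitor, a higher number a weaker inhibitor:
compound 1 `O=C(NO)c1ccc(Cn2nnc(-c3ccc(C(F)(F)F)cc3)n2)cc1` gives 11 nM
compound 2 `Nc1ccc(C(=O)NO)cc1` gives 1400 nM

Compound 1 has the lowest number of the two; compound 2 stands a long way above it, and that gap is well beyond the scatter of repeated measurements. Among the measured compounds shown here, no pair differing in a single place has been measured, so no measured step is available to calibrate the change under study.

Compound 3 `O=C(NO)c1ccc(Cn2nnc(-c3ccccc3)n2)cc1` differs from compound 1 by hydrogen in place of trifluoromethyl on an aromatic carbon, para to a large group. The rest of the shared core is unchanged. For the measured compounds named here, with no comparable step in this assay, the size of the change is an estimate: a small loss in this assay is expected, close to the scatter but possibly a little beyond it, with a hydroxamic acid core still present. For compound 3 the expected step is a 2.3-fold higher number from compound 1 to compound 3 (0.36 log units; beyond the scatter). Compound 3 is estimated at 25 nM, with a range from 8 nM to 80 nM.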

Compound 3, half-maximal inhibitory concentration: 3 nM
The estimate for compound 3 lay 8.3-fold (0.92 log units) above the measured number; measured number below the stated range.
By their numbers in this assay, from the lowest: compound 3; then compound 1; then compound 2.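

Hydrogen in place of trifluoromethyl on this aromatic carbon, para to a large group, gives in this assay the first single-place step of the series: a 3.7-fold lower number from compound 1 to compound 3 (0.56 log units; beyond the scatter), a modest change that lies beyond the scatter. For this pair, a low number therefore does not depend on the trifluoromethyl, and the position carrying only hydrogen gives the lower number. Nothing at hand bears on the reason for this shift.

Open, as far as these compounds go, is how other groups on the same aromatic carbon, such as a chlorine atom, a methoxy group or an amine, would compare with hydrogen and trifluoromethyl. Also open, from the compounds shown here alone, is whether a step of this size would hold on a core other than that of compound 1.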